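This account rests on a few compounds, and the source may have more. Where it says the series, first, only, none or still open, it means among the compounds named here.

Compound 1 `Cc1ccc(S(=O)(=O)N[C@@H](CC(=O)NC(C)(C)C)C(=O)NCCNC(=O)c2cc(C)ccc2F)cc1` is measured in an ADME assay on HepG2 cells (Homo sapiens) for cytotoxicity (on this read-out lower numbers stand for an effect already at smaller amounts and higher numbers for an effect only at larger amounts of compound), and reaches only the limit of the assay, > 11000 nM.
Compound 2 `Cc1ccc(S(=O)(=O)N[C@@H](CC(=O)NC(C)(C)C)C(=O)NCCNC(=O)c2c(O)cccc2F)cc1` likewise gives only a limit, > 11000 nM.
Compound 3 `Cc1ccc(S(=O)(=O)N[C@@H](CC(=O)NC(C)(C)C)C(=O)NCCNC(=O)c2cc(Cl)ccc2Cl)cc1` also stops at a limit, > 11000 nM.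

Compound 2 therefore stands at the limit in this assay, and the two other values shown are limits too. The step from compound 2 to compound 4 `Cc1ccc(S(=O)(=O)N[C@@H](CC(=O)NC(C)(C)C)C(=O)NCCNC(=O)c2ccccc2F)cc1` is hydrogen in place of hydroxy on an aromatic carbon. For the measured compounds named here, of the measured steps, the one from compound 1 to compound 2 is a step that the two limits leave unreadable from compound 1 to compound 2, the one from compound 1 to compound 3 is a step that the two limits leave unreadable from compound 1 to compound 3, and the one from compound 2 to compound 3 is a step that the two limits leave unreadable from compound 2 to compound 3; all three sit at the limit of > 11000 nM in this assay, at which 3 of the 3 values shown sit, so none of them gives a readable size. Going by the values given here, no step that bears on compound 4 can be read, and the expectation for it is no step beyond the scatter, with compound 4 most likely also reported only as a limit. The expected step is a number no higher from compound 2 to compound 4 (the limit leaves the size open). Compound 4 is estimated at 11000 nM, within 5000 nM to 30000 nM.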

Compound 4, half-maximal effective concentration: > 11000 nM
Compound 4 ended at the assay's limit; the forecaster's own chance of this, stated with the estimate: 85%; the middle value lies on the limit itself.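

Compound 4 gives only a limit of the assay, > 11000 nM. Its steps to compound 1, compound 2 and compound 3 cannot be read, so this result yields no new step: the limit of > 11000 nM in this assay, at which 4 of the 4 values shown sit.

The compounds shown leave open at what concentration, if any, these four compounds would have an effect in this assay, and whether their substituent changes would alter it.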